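The source may report more compounds than this note shows. Statements on the series, on what has been measured and on what is new or still open speak of the compounds shown alone.

Three compounds serve as the background for compound 4. Compound 1 `C[Si](C)(C)OC(C#N)C1CCC1` carries a cyclobutyl group; in an assay on isolated protein for inhibition of Phenylethanolamine N-methyltransferase (Bos taurus) (on this read-out lower numbers stand for stronger inhibition and higher numbers for weaker inhibition), compound 1 gives only > 1000000 nM, which is a limit of the assay and not a number (the limit of > 1000000 nM in this assay, at which 1 of the 3 values shown sits). Compound 2 `NCC(O)C1CCCCCC1` is an aminoalcohol with a cycloheptyl group, and in this assay compound 2 gives 8000 nM. Compound 3 `CCCCCC(C#N)O[Si](C)(C)C` is a silyl-protected cyanohydrin with a straight pentyl chain; in this assay compound 3 gives 314000 nM, the highest of the two numbers reported, which puts it well beyond the scatter away from compound 2.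

Compound 4 `CCCCCCC(C#N)O[Si](C)(C)C` differs from compound 3 by methyl in place of hydrogen on a saturated chain carbon, six bonds along the chain from an oxygen on an unsaturated carbon and a triple-bonded carbon, that is, the chain is lengthened from pentyl to hexyl. The shift from compound 3 to compound 4 is expected to be a 2.1-fold lower number from compound 3 to compound 4 (0.32 log units; beyond the scatter), a modest move towards stronger inhibition. Compound 4 is therefore estimated at 150000 nM, within a range from 40000 nM to 600000 nM.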

Compound 4, half-maximal inhibitory concentration: 109000 nM
Compound 4: middle estimate off by 1.4-fold (0.14 log units), on the high side; low and high end bracket the measured number.
By their numbers in this assay, from the lowest: compound 2; then compound 4; then compound 3. At a limit, above all of these: compound 1.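

Lengthening the chain from pentyl to hexyl, with methyl in place of hydrogen on a saturated chain carbon, gives a 2.9-fold lower number from compound 3 to compound 4 (0.46 log units; beyond the scatter) and so shows that this far along the chain a change of one methyl still registers in the read-out. This pair is the first shown that differs in one place, so it gives the first direct reading of this position, which the earlier compounds could not provide. No measured property shown here bears on this step.

As far as these compounds go, a single step sets no trend, so it remains open whether a longer chain, such as heptyl or octyl, would continue in the same direction or reverse it. Also open, from the compounds shown here alone, is how a branched chain or a hydroxyl group at this position would compare with the hexyl chain of compound 4.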